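Swapping one ring group on the shared core

The source may hold more compounds than are shown below. What is called first, only, known or untested is meant among the compounds shown, and "the series" means these compounds.

Measured so far in a physicochemical assay for solubility, in phosphate buffer, at pH 7.4 (a lower number here means a less soluble compound, a higher number a more soluble compound), are three compounds:
- compound 1 `CC(=O)N[C@@H]1CCC[C@H](C(=O)Nc2cc(-c3cnn4c3CCCC4)c(Cl)cn2)C1` gives 310000 nM
- compound 2 `CC(=O)N[C@@H]1CCC[C@H](C(=O)Nc2cc(-c3cnc4n3CCCC4)c(Cl)cn2)C1` gives 600000 nM
- compound 3 `CC(=O)N[C@@H]1CCC[C@H](C(=O)Nc2cc(-c3cnc4n3CCC4)c(Cl)cn2)C1` gives 490000 nM

Compound 3 at 490000 nM lies within the scatter of both other compounds. Going on to compound 4 `CC(=O)N[C@@H]1CCC[C@H](C(=O)Nc2cc(-c3cnn4c3OCCC4)c(Cl)cn2)C1` brings the change (a group of 9 heavy atoms (6 carbon, 2 nitrogen, 1 oxygen; one five-membered aromatic ring with 2 hetero atoms, one six-membered non-aromatic ring with 2 hetero atoms) in place of a group of 8 heavy atoms (6 carbon, 2 nitrogen; one five-membered non-aromatic ring with 1 hetero atom, one five-membered aromatic ring with 2 hetero atoms), on an aromatic carbon). Three measured steps exchange one ring group for another on that carbon. These are a 1.9-fold higher number from compound 1 to compound 2 (0.29 log units; within the scatter) and a 1.6-fold higher number from compound 1 to compound 3 (0.20 log units; within the scatter) and also a 1.2-fold lower number from compound 2 to compound 3 (0.09 log units; within the scatter) and all of them stay within the scatter. Among the compounds with values here, no measured compound carries oxygen in this group, so that part of the change remains untested. On these three steps, the expected change is a 1.1-fold lower number from compound 3 to compound 4 (0.04 log units; within the scatter) and no step beyond the scatter is expected. In this assay the estimate for compound 4 is 450000 nM and the expected range runs from 220000 nM up to 900000 nM for this compound.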

Compound 4, solubility: 110000 nM
Estimate against measurement, compound 4: 4.1-fold (0.61 log units) above, and the stated range ends above it.
By their numbers in this assay, from the lowest: compound 4; then compounds 1, 3 and 2 (each within the scatter of the next).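

In this assay the three earlier ring groups on this aromatic carbon stayed within the scatter of one another, so the position had shown no sensitivity to the change of group; the group with oxygen in its six-membered non-aromatic ring is the first to move the number beyond the scatter, with a 4.5-fold lower number from compound 3 to compound 4 (0.65 log units; beyond the scatter) and a 5.5-fold lower number from compound 2 to compound 4 (0.74 log units; beyond the scatter) as its steps. The step closest in structure is a 2.8-fold lower number from compound 1 to compound 4 (0.45 log units; beyond the scatter) and it is also beyond the scatter, since those two groups have the same ring sizes and differ by one oxygen in place of one carbon. Nothing among the data shown explains the lower number for compound 4.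

The compounds shown carry this oxygen at a single place in the ring, so another placement remains open. On these data alone, whether an amine nitrogen or a hydroxyl group in that six-membered ring would give a number like that of compound 4 is also open.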